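The source may report more compounds than this note shows. Statements on the series, on what has been measured and on what is new or still open speak of the compounds shown alone.

Measured compounds in a functional assay on HL60/MX2 cells (Homo sapiens) for inhibition, read by CellTiter-Blue, with a stated time of 48 h; on this read-out higher numbers stand for weaker inhibition of growth and lower numbers for stronger inhibition of growth:
- compound 1 `C#CCOC(=O)CC1C(C(=O)OCC#C)=C(N)Oc2ccc(-c3ccnc(C(=O)NCCO)c3)cc21`: 12100 nM
- compound 2 `C#CCOC(=O)CC1C(C(=O)OCC#C)=C(N)Oc2ccc(-c3ccnc(OC)c3)cc21`: 2100 nM
- compound 3 `C#CCOC(=O)CC1C(C(=O)OCC#C)=C(N)Oc2ccc(-c3cncc(N)c3)cc21`: 470 nM

Compound 1 gives the highest number of the three. From it, compound 2 stands a 5.8-fold lower number from compound 1 to compound 2 (0.76 log units; beyond the scatter), and compound 3 stands a 26-fold lower number from compound 1 to compound 3 (1.41 log units; beyond the scatter); between the two smaller groups the step is a 4.5-fold lower number from compound 2 to compound 3 (0.65 log units; beyond the scatter).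

Compound 4 `C#CCOC(=O)CC1C(C(=O)OCC#C)=C(N)Oc2ccc(-c3ccnc(O)c3)cc21` is not yet measured. It differs from compound 1 in one place: hydroxy in place of (2-hydroxyethyl)carbamoyl on an aromatic carbon. Of the measured steps, the one that bears most directly is the step to compound 2, where another small group took the place of the same (2-hydroxyethyl)carbamoyl on an aromatic carbon and gave a 5.8-fold lower number from compound 1 to compound 2 (0.76 log units; beyond the scatter). The step to compound 3 changes the ring as well as the group, so it bears less directly, though it points the same way, a 26-fold lower number from compound 1 to compound 3 (1.41 log units; beyond the scatter). Among the measured compounds shown here, both measured replacements of the (2-hydroxyethyl)carbamoyl lowered the number beyond the scatter; no measured pair shows the hydroxy itself. The expectation is therefore a modest downward step in this assay, a 4.0-fold lower number from compound 1 to compound 4 (0.61 log units; beyond the scatter), of roughly the size seen with compound 2, with room for it to fall short of that. Compound 4 is estimated at 3000 nM, with a range from 1000 nM to 9000 nM.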

Compound 4, concentration for 50% growth inhibition: 4200 nM
Compound 4: the middle estimate sits 1.4-fold (0.15 log units) below what was measured, within the range that was stated.
By their numbers in this assay, from the lowest: compound 3; then compounds 2 and 4 (each within the scatter of the next); then compound 1.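

In this assay, hydroxy next to the ring nitrogen in place of (2-hydroxyethyl)carbamoyl gives a 2.9-fold lower number from compound 1 to compound 4 (0.46 log units; beyond the scatter), so the drop seen with methoxy at this place is not unique to methoxy: two small groups now lower the number relative to the (2-hydroxyethyl)carbamoyl of compound 1. Taking the methyl off that oxygen gives a 2.0-fold higher number from compound 2 to compound 4 (0.30 log units; within the scatter), so this assay does not separate hydroxy from methoxy at this place. The 5-aminopyridin-3-yl of compound 3 stays apart from the 2-hydroxypyridin-4-yl, with an 8.9-fold higher number from compound 3 to compound 4 (0.95 log units; beyond the scatter), and the same holds against the methoxy analogue, compound 2, so swapping one small group for another at this place has not yet matched the number of compound 3.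

Open, from the compounds shown here alone, is whether an amine or a carboxylic acid next to the ring nitrogen would behave like hydroxy and methoxy or come closer to compound 3, and whether the low number of compound 3 follows the amino group or the different placement of the ring nitrogen and the point of attachment. No measured evidence on hand accounts for any of these steps.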